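Working notes: 3-cyanophenyl to 4-cyanophenyl

The source may hold more compounds than are shown below. What is called first, only, known or untested is meant among the compounds shown, and "the series" means these compounds.

Measured so far:
Compound 1 `O=C(Nc1ccc(Cl)cc1)N1CCC[C@H]1c1nc(-c2cccc(Br)c2)no1` gives > 50000 nM as a limit
Compound 2 `N#Cc1cccc(-c2noc([C@@H]3CCCN3C(=O)Nc3ccc(Cl)cc3)n2)c1` gives > 50000 nM as a limit

In an ADME assay on MCF-10A cells (Homo sapiens) for inhibition, with a stated time of 48 h (on this read-out higher numbers stand for weaker inhibition and lower numbers for stronger inhibition), compound 2 stands at > 50000 nM as a limit of the assay and not as a number. Among the measured compounds shown here, the series so far offers only the limit of > 50000 nM in this assay, at which 2 of the 2 values shown sit, and no numeric value.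

Compound 3 `N#Cc1ccc(-c2noc([C@@H]3CCCN3C(=O)Nc3ccc(Cl)cc3)n2)cc1` carries 4-cyanophenyl in place of 3-cyanophenyl on an aromatic carbon and has the same atoms as compound 2, joined differently.

For the measured compounds named here, the one measured step that bears on this is a step that the two limits leave unreadable from compound 1 to compound 2 with cyano in place of bromo on an aromatic carbon, so it provides no size to carry over. With compound 2 at > 50000 nM as a limit, another limit is the expected outcome, and no step beyond the scatter is expected in this assay in either direction. The estimated move is a number no higher from compound 2 to compound 3 (the limit leaves the size open) on this reasoning. For compound 3 the estimate is 50000 nM with an expected range from 25000 nM to 100000 nM in this read-out.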

Compound 3, half-maximal inhibitory concentration: > 50000 nM
Compound 3 ended at the assay's limit; the forecaster's own chance of this, stated with the estimate: 85%; the middle value sits exactly at the limit.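

In this assay compound 3 gives > 50000 nM, a limit of the assay and not a number. No step can be read among compound 1, compound 2 and compound 3: the limit of > 50000 nM in this assay, at which 3 of the 3 values shown sit.

The compounds shown leave open how strongly each inhibits in this assay, and whether 3-bromophenyl, 3-cyanophenyl and 4-cyanophenyl differ there at all.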